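Adding one methyl to compound 2

The compounds below may be only part of what the source reports. "The series", "measured", "known", "first", "only" and "open" are said of these compounds alone.

In a functional assay on MV4-11 cells (Homo sapiens) for inhibition, read by resazurin assay, with a stated time of 72 h (a lower number here means a stronger inhibitor of growth, a higher number a weaker inhibitor of growth), compound 1 `O=C1NCCC12CCN(c1c(Cl)cncc1-c1ccc(Cl)s1)CC2` gives 560 nM and compound 2 `O=Cc1ccc(-c2cncc(Cl)c2N2CCC3(CCNC3=O)CC2)s1` gives 750 nM. Placing formyl in place of chloro on an aromatic carbon produced a 1.3-fold higher number from compound 1 to compound 2 (0.13 log units; within the scatter), so these two numbers do not separate the pair, and compound 2 stands level with the only other measured compound.

Compound 3 `Cc1cc(-c2cncc(Cl)c2N2CCC3(CCNC3=O)CC2)sc1C=O` carries one further change, (methyl in place of hydrogen on an aromatic carbon). This is methyl in place of hydrogen on an aromatic carbon, next to the ring atom that bears the formyl group. Going by the values given here, no measured step shows what such a methyl does. Among the compounds with values here, the only measured step, a 1.3-fold higher number from compound 1 to compound 2 (0.13 log units; within the scatter), is a different swap, and it gives no reason to expect a shift beyond the scatter in this assay. The estimated change is small: a 1.1-fold lower number from compound 2 to compound 3 (0.03 log units; within the scatter). For compound 3 the expected value is 700 nM, with an estimated range from 280 nM to 1700 nM.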

Compound 3, concentration for 50% growth inhibition: 2530 nM
Compound 3: middle estimate off by 3.6-fold (0.56 log units), on the low side; the measured number lies above the stated range.
By their numbers in this assay, from the lowest: compounds 1 and 2 (each within the scatter of the next); then compound 3.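

A single added methyl, the smallest of changes, is enough to move the result in this assay: placed next to the ring atom that bears the formyl group, it gives a 3.4-fold higher number from compound 2 to compound 3 (0.53 log units; beyond the scatter). The earlier swap of chloro for formyl did not separate compounds, whereas the full change from 5-chlorothiophen-2-yl to 5-formyl-4-methylthiophen-2-yl gives a 4.5-fold higher number from compound 1 to compound 3 (0.65 log units; beyond the scatter), which makes compound 3 the weakest inhibitor of growth of the three. Nothing available explains why this methyl weakens growth inhibition.

From the compounds shown here alone, the methyl appears here only on a ring that also carries formyl, so it remains open whether it would have the same effect beside chloro or another group. Also open, going by these compounds, is how an ethyl, a methoxy group or a fluorine would read at this same ring position.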